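The source may hold more compounds than are shown below. What is called first, only, known or untested is meant among the compounds shown, and "the series" means these compounds.

Measured so far in an ADME assay on HEp-2 cells (Homo sapiens) for cytotoxicity, with a stated time of 4 days; on this read-out higher numbers stand for lower toxicity in this test and lower numbers for higher toxicity in this test:
- compound 1 `CS(=O)(=O)CCn1c(Cn2c(S(C)(=O)=O)cc3ccccc32)nc2ccccc21`: > 100000 nM (a limit of the assay)
- compound 2 `CNS(=O)(=O)c1cn(Cc2nc3cc(Cl)ccc3n2CCCS(C)(=O)=O)c2ccccc12`: > 100000 nM (a limit of the assay)
- compound 3 `CS(=O)(=O)c1nn(Cc2nc3cc(Cl)ccc3n2CCO)c2cnccc12`: > 100000 nM (a limit of the assay)

Compound 1 gives > 100000 nM in this assay, which is a limit and not a number. Compound 2 likewise gives > 100000 nM, again a limit. Compound 3 gives > 100000 nM, also a limit. Compound 3 therefore stands exactly where the whole series stands so far: the limit of > 100000 nM in this assay, at which 3 of the 3 values shown sit. Going by the values given here, no pair of measured compounds differs in one place only, so no measured step is available to gauge how a single change moves this read-out.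

Compound 4 `CC(C)(CO)Cn1c(Cn2nc(S(C)(=O)=O)c3ccncc32)nc2cc(Cl)ccc21` is the next to be tested. Against compound 3 the change is 1-(hydroxymethyl)-1-methylethyl in place of hydroxymethyl on a saturated chain carbon bound to an aromatic nitrogen; cut one bond further out, it reads 2-hydroxyethyl to 2-(hydroxymethyl)-2-methylpropyl. Nothing in the measured set speaks for a step in either direction, and with every value at the limit of > 100000 nM in this assay, at which 3 of the 3 values shown sit, the expectation for the step from compound 3 to compound 4 is none beyond the scatter, a number no higher from compound 3 to compound 4 (the limit leaves the size open). Compound 4 is thus estimated at 100000 nM, with a range from 50000 nM to 200000 nM, most likely reported once more as a limit rather than a number.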

Compound 4, half-maximal cytotoxic concentration: > 100000 nM
Compound 4 ended at the assay's limit (the forecaster's own chance of this, stated with the estimate: 85%); the middle value lies on the limit itself.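

Compound 3 and compound 4 both sit at a limit of this assay, so no step can be read between them: the limit of > 100000 nM in this assay, at which 4 of the 4 values shown sit.

The compounds shown leave open whether any change, including 2-(hydroxymethyl)-2-methylpropyl in place of 2-hydroxyethyl, moves this read-out at all, and at what concentration any of them would turn toxic in this assay.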